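The source may report more compounds than this note shows. Statements on the series, on what has been measured and on what is new or still open speak of the compounds shown alone.

In an ADME assay on microsomes from liver (Rattus norvegicus) for metabolic stability, read by LC-MS, with a stated time of 10 min, tested at 0.5 uM (a lower number here means that less of the compound is left, a higher number that more of the compound is left), compound 1 `c1ccc2c(c1)CN[C@@H](CN(CC1CCNCC1)[C@H]1CCCc3cccnc31)C2` gives 65% and compound 2 `c1ccc2c(c1)CN[C@@H](CN(CCCN1CCNCC1)[C@H]1CCCc3cccnc31)C2` gives 100% while compound 3 `CC(C)N1CCN(CCCN(C[C@H]2Cc3ccccc3CN2)[C@H]2CCCc3cccnc32)CC1` stands lowest of the three at 4% on this measure. Compound 4 `c1ccc2c(c1)CN[C@@H](CN(CCN1CCNCC1)[C@H]1CCCc3cccnc31)C2` differs from compound 3 by piperazin-1-yl in place of (4-isopropylpiperazin-1-yl)methyl on a saturated chain carbon, two bonds along the chain from an amine nitrogen in one place, with piperazin-1-yl in place of (4-isopropylpiperazin-1-yl)methyl on a saturated chain carbon, two bonds along the chain from an amine nitrogen. The closest measured evidence is a number 96 percentage points lower from compound 2 to compound 3 (beyond the scatter) when isopropyl replaces hydrogen on an amine nitrogen in a ring, and compound 4 carries no such isopropyl. The steps of a number 35 percentage points higher from compound 1 to compound 2 (beyond the scatter) and a number 61 percentage points lower from compound 1 to compound 3 (beyond the scatter) are also large and show that changes at this same place can move the number a long way, in either direction. Among the compounds with values here, no measured step isolates the rest of the change, so the range has to stay wide. Expected here is a number 81 percentage points higher from compound 3 to compound 4 (beyond the scatter) as a large rise beyond the scatter. Compound 4 is estimated at 85% in this assay with a range from 55% to 100% expected.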

Compound 4, percent of the compound remaining: 62%
Beside the measured number, compound 4's estimate is 23 percentage points above it, within the range that was stated.
By their numbers in this assay, from the lowest: compound 3; then compounds 4 and 1 (each within the scatter of the next); then compound 2.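

In this assay, within the data shown here, the step of a number 38 percentage points lower from compound 2 to compound 4 (beyond the scatter) is the first sign that the chain carrying the piperazine ring matters by itself, since the ring has no isopropyl in either compound and only 2-(piperazin-1-yl)ethyl gives way to (piperazin-1-yl)methyl. The step of a number 58 percentage points higher from compound 3 to compound 4 (beyond the scatter) combines that change with the loss of the isopropyl, so it cannot be divided between the two. The step of a number 3 percentage points lower from compound 1 to compound 4 (within the scatter) shows that piperidin-4-yl and (piperazin-1-yl)methyl cannot be told apart in this assay.

No measurement offered here explains any of these differences. Still open, as far as these compounds go, is whether a 4-isopropylpiperazin-1-yl group on the shorter chain would give a drop as large as the isopropyl gave on the longer one, and how a 3-(piperazin-1-yl)propyl group would behave.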